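The compounds below may be only part of what the source reports. "The series", "measured", "known", "first", "only" and "open" are said of these compounds alone.

Compound 1 `Cc1ccc(NC(=S)NC(=O)c2ccc(OCc3cccc(Cl)c3)cc2)cc1-c1nc2ccccc2[nH]1` gives only a limit in a functional assay on SW-620 cells (Homo sapiens) for inhibition, read by MTT assay, with a stated time of 48 h; a higher number here means a weaker inhibitor, a lower number a stronger inhibitor: compound 1 shows > 100000 nM.
Compound 2 `Cc1ccc(NC(=S)NC(=O)c2ccc(OCc3ccc(C(F)(F)F)cc3)cc2)cc1-c1nc2ccccc2[nH]1` gives 72400 nM in this assay.
Compound 3 `Cc1ccc(NC(=S)NC(=O)c2ccc(OCc3cccc(Cl)c3Cl)cc2)cc1-c1nc2ccccc2[nH]1` gives only a limit in this assay: compound 3 shows > 100000 nM.

Compound 3 thus stands at the limit of this assay, a point it shares with compound 1 (the limit of > 100000 nM in this assay, at which 2 of the 3 values shown sit). The step of an at least 1.3-fold higher number from compound 2 to compound 3 (0.14 log units; that floor lies within the scatter) is readable only as a floor, and the step that the two limits leave unreadable from compound 1 to compound 3 cannot be read at all. Compound 4 `Cc1ccc(NC(=S)NC(=O)c2ccc(OCc3cccc(F)c3)cc2)cc1-c1nc2ccccc2[nH]1` differs from compound 3 in one place: 3-fluorophenyl in place of 2,3-dichlorophenyl on a saturated chain carbon bound to an oxygen on an aromatic ring. Two measured steps alter the same phenyl group. The step of an at least 1.3-fold lower number from compound 1 to compound 2 (0.14 log units; that floor lies within the scatter) and the step of an at least 1.3-fold higher number from compound 2 to compound 3 (0.14 log units; that floor lies within the scatter) both rest on floors that lie within the scatter, so no change of this kind has yet moved the number beyond the scatter. Compound 4 is therefore expected to remain near the limit, and the step of a number no higher from compound 3 to compound 4 (the limit leaves the size open) is expected to be no larger than the scatter. The estimate for compound 4 in this assay is 100000 nM, with a range from 40000 nM to 250000 nM.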

Compound 4, half-maximal inhibitory concentration: > 100000 nM
Compound 4: a limit, no number (the forecaster's own chance of this, stated with the estimate: 65%); the middle value sits exactly at the limit.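

With 3-fluorophenyl on a saturated chain carbon bound to an oxygen on an aromatic ring, compound 4 gives > 100000 nM in this assay, which is a limit and not a number. Within the data shown here, the only readable step is an at least 1.3-fold higher number from compound 2 to compound 4 (0.14 log units; that floor lies within the scatter), and the steps that link compound 4 to compound 1 and to compound 3 cannot be read. A fluorine-bearing phenyl group now joins 3-chlorophenyl and 2,3-dichlorophenyl at this place in giving no number, leaving compound 2 as the only compound shown with one: the limit of > 100000 nM in this assay, at which 3 of the 4 values shown sit.

How far the number can move at this place remains open, as no step shown is readable beyond the scatter. Whether a phenyl group carrying an amine or a carboxylic acid, or a longer chain before the phenyl group, would give a clearly lower number also stays unanswered.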